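The source may hold more compounds than are shown below. What is called first, only, known or untested is meant among the compounds shown, and "the series" means these compounds.

Working notes on the series. In a functional assay on A549 cells (Homo sapiens) for antiproliferative activity, read by MTT assay, with a stated time of 72 h (a higher number here means a weaker inhibitor, a lower number a stronger inhibitor), compound 1 (`COc1ncc(-c2ccc3c(c2)N(C2CCCCC2)C(=O)CO3)cc1NS(=O)(=O)c1ccc(F)cc1`) gives 24600 nM. Compound 2 (`COc1cccc(N2C(=O)COc3ccc(-c4cnc5ccccc5c4)cc32)c1`) is recorded only as a limit, > 40000 nM, and not as a number. That leaves compound 2 without an exact place in the series, and the reading is set by the limit of > 40000 nM in this assay, at which 1 of the 2 values shown sits. For the measured compounds named here, no step between the two measured compounds is available, so the effect of a single change cannot be read from the data so far.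

Compound 3 (`COc1ccc(N2C(=O)COc3ccc(-c4cnc5ccccc5c4)cc32)cc1`) has the same atoms as compound 2, joined differently, with 4-methoxyphenyl in place of 3-methoxyphenyl on an amide-type nitrogen in a ring. Going by the values given here, no measured pair shows what this change does. In this assay, no step beyond the scatter is expected, and no direction can be favoured. The assay may again report only a limit for compound 3. If a number is obtained, compound 3 is expected at 35000 nM, within an estimated range of 12000 nM to 60000 nM. The expected size of the change is an at least 1.1-fold lower number from compound 2 to compound 3 (0.05 log units; that floor lies within the scatter).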

Compound 3, half-maximal inhibitory concentration: > 40000 nM
Compound 3: only a limit was reported; the forecaster's own chance of this, stated with the estimate: 60%; middle value at least 1.1-fold (0.05 log units) away from the limit.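

In this assay compound 3 is recorded only as a limit, > 40000 nM. For the compounds shown here, with compound 2 also held only by a limit, no step between compound 2 and compound 3 can be read: the limit of > 40000 nM in this assay, at which 2 of the 3 values shown sit. The compounds shown leave open whether 4-methoxyphenyl in place of 3-methoxyphenyl on the amide-type nitrogen changes antiproliferative activity at all.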